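The source may report more compounds than this note shows. Statements on the series, on what has been measured and on what is new or still open speak of the compounds shown alone.

Measured so far: compound 1 `CCc1nc(N)nc(N)c1-c1ccc(NCc2ccnc(Cl)c2)cc1` gives 220 nM in a functional assay on CHOK cells for antagonist activity at growth hormone secretagogue receptor type 1 (Homo sapiens), read by calcium flux; on this read-out higher numbers stand for weaker inhibition and lower numbers for stronger inhibition; compound 2 `Nc1nc(N)c(-c2ccc(NCc3ccnc(Cl)c3)cc2)c(COCc2ccccc2)n1` gives 3.6 nM in this assay.

Compound 2 holds the lowest of the two numbers, with compound 1 nearest. Among the measured compounds shown here, the only measured step, a 61-fold lower number from compound 1 to compound 2 (1.79 log units; beyond the scatter), concerns the chain carbon bound to an aromatic carbon and leaves the arylmethyl group on the amine untouched. Compound 3 `Nc1nc(N)c(-c2ccc(NCc3cnc4ccccc4c3)cc2)c(COCc2ccccc2)n1` carries quinolin-3-yl in place of 2-chloropyridin-4-yl on a saturated chain carbon bound to a nitrogen on an aromatic ring. For the measured compounds named here, no measured step touches this position, so there is no direct guide to the size or direction of the change in this assay. The step is estimated as a 2.2-fold higher number from compound 2 to compound 3 (0.35 log units; beyond the scatter). Compound 3 is expected at 8 nM, within 2 nM to 40 nM.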

Compound 3, half-maximal inhibitory concentration: 780 nM
Compound 3: the middle estimate sits 98-fold (1.99 log units) below what was measured; the measured number lies above the stated range.
By their numbers in this assay, from the lowest: compound 2; then compound 1; then compound 3.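

In this assay, the position on a saturated chain carbon bound to a nitrogen on an aromatic ring proves highly sensitive to the aryl group it carries: quinolin-3-yl in place of 2-chloropyridin-4-yl gives a 220-fold higher number from compound 2 to compound 3 (2.34 log units; beyond the scatter). The benzyloxy group of compound 2 therefore does not preserve the low number when this aryl group changes. Nothing available explains this step.

This single swap changes the chlorine and the ring system together, leaving their separate contributions unresolved. An unsubstituted pyridin-4-yl or a quinolin-4-yl group would help separate them.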